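Aryl swap on the chalcone of compound 1: expected potency

The source may hold more compounds than are shown below. What is called first, only, known or untested is meant among the compounds shown, and "the series" means these compounds.

Measured compounds:
compound 1 `CC(C)(C)c1ccc(/C=C/C(=O)c2ccc(OCC(=O)N[C@H]3CCOC3=O)cc2)cc1` gives 17200 nM
compound 2 `CC(C)c1ccc(NCC(=O)N[C@H]2CCOC2=O)cc1` gives > 64000 nM
compound 3 `O=C(CNc1ccc(Cl)cc1Cl)N[C@H]1CCOC1=O` gives > 64000 nM

In a functional assay on MGC-803 cells (Homo sapiens) for antiproliferative activity, read by MTT assay, with a stated time of 72 h (on this read-out higher numbers stand for weaker inhibition and lower numbers for stronger inhibition), compound 1 gives 17200 nM, the only numerical result in this set. For compound 2 the value > 64000 nM is a limit of the assay, not a number. For compound 3 the value > 64000 nM is likewise a limit. Within the data shown here, compound 1 therefore stands apart from the rest because of the limit of > 64000 nM in this assay, at which 2 of the 3 values shown sit; no step between two measured compounds is available.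

Compound 4 `O=C(COc1ccc(C(=O)/C=C/c2cccc(Cl)c2)cc1)N[C@H]1CCOC1=O` is the next candidate. It differs from compound 1 by 3-chlorophenyl in place of 4-(tert-butyl)phenyl on a double-bonded chain carbon bound to a double-bonded chain carbon. Among the measured compounds shown here, with no measured step of this kind, the expectation rests on compound 1 alone, and the change is expected to move the result by no more than the usual scatter, in either direction. Compound 4 is estimated to give 12000 nM in this assay, with a range from 4000 nM to 40000 nM. That estimate amounts to an expected step of a 1.4-fold lower number from compound 1 to compound 4 (0.16 log units; within the scatter).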

Compound 4, half-maximal inhibitory concentration: 29100 nM
Compound 4: middle estimate off by 2.4-fold (0.38 log units), on the low side; low and high end bracket the measured number.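

In this assay, exchanging 4-(tert-butyl)phenyl for 3-chlorophenyl on a double-bonded chain carbon bound to a double-bonded chain carbon gives a 1.7-fold higher number from compound 1 to compound 4 (0.23 log units; within the scatter). Among these compounds, this is the first measured step at this position, and it shows that this pair of aryl groups cannot be told apart in this assay, so the tert-butyl group is not required here for compound 4 to return a numerical value. Nothing measured here accounts for the size of the step.

The exchange alters both the substituent and its place on the phenyl ring, so the two changes cannot be separated without a partner such as 4-chlorophenyl. Also open, on these data alone, is whether a phenyl ring carrying an amine or a carboxylic acid at this position would stay within the same range.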